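Changing the Aryl Group on an Aromatic Nitrogen

The compounds below may be only part of what the source reports. "The series", "measured", "known", "first", "only" and "open" are said of these compounds alone.

Compound 1 `N#CC1=C(N)Oc2c(c3nc4ccccc4nc3c3ccccc23)C12C(=O)N(Cc1cnnn1-c1ccc(F)c(Cl)c1)c1ccccc12` and compound 2 `N#CC1=C(N)Oc2c(N)cc3nc4ccccc4nc3c2C12C(=O)N(Cc1cnnn1-c1cccc(C(F)(F)F)c1)c1ccccc12` share a core and were tested in a functional assay on A549 cells (Homo sapiens) for antiproliferative activity, read by MTT assay, with a stated time of 48 h; a higher number here means a weaker inhibitor, a lower number a stronger inhibitor. For compound 1 the result is only a limit of the assay, > 50000 nM. Among the measured compounds shown here, compound 2 gives 5400 nM, the only number among the two values shown. Compound 3 `N#CC1=C(N)Oc2c(N)cc3nc4ccccc4nc3c2C12C(=O)N(Cc1cnnn1-c1ccc(Cl)cc1Cl)c1ccccc12` differs from compound 2 in one place: 2,4-dichlorophenyl in place of 3-(trifluoromethyl)phenyl on an aromatic nitrogen. No measured step of this kind is shown, so this change is expected to move the result in this assay by no more than the usual scatter, in no clear direction. Compound 3 is therefore expected to give 6000 nM, between 2000 nM and 20000 nM, an expected step of a 1.1-fold higher number from compound 2 to compound 3 (0.05 log units; within the scatter).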

Compound 3, half-maximal inhibitory concentration: > 50000 nM
Compound 3 was reported as a limit; the forecaster's own chance of this, stated with the estimate: 15%; at least 8.3-fold (0.92 log units) between middle value and limit.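

On the aromatic nitrogen, the choice of aryl group can matter: 2,4-dichlorophenyl in place of 3-(trifluoromethyl)phenyl gives an at least 9.2-fold higher number from compound 2 to compound 3 (0.96 log units; beyond the scatter) in this assay. Among the compounds shown here, the earlier compounds offered no measured step at this position, so this is the first sign of how much it can matter. The result for compound 3 is a limit, not a number: the limit of > 50000 nM in this assay, at which 2 of the 3 values shown sit.

The compounds shown do not separate the loss of the trifluoromethyl group from the arrival of the two chlorine atoms. On these data alone, whether a plain phenyl, or an aryl group carrying an amine or a carboxylic acid, would hold the result of compound 2 remains open.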